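The source may report more compounds than this note shows. Statements on the series, on what has been measured and on what is new or still open speak of the compounds shown alone.

Compound 1 `COc1cc(/C=C/C(=O)/C=C(/C=C/c2ccc(OC(C)=O)c(OC)c2)NC2CCCCC2)ccc1OC(C)=O`: 4400 nM
Compound 2 `COc1cc(/C=C/C(=O)/C=C(/C=C/c2ccc(OC(C)=O)c(OC)c2)NCC(C)C)ccc1OC(C)=O`: > 25000 nM, a limit
Compound 3 `COc1cc(/C=C/C(=O)/C=C(/C=C/c2ccc(O)c(OC)c2)NC2CCCCC2)ccc1O`: 5100 nM

These values come from a functional assay on Caco-2 cells (Homo sapiens) for inhibition, read by sulforhodamine B assay, with a stated time of 72 h; a higher number here means a weaker inhibitor, a lower number a stronger inhibitor. Compound 2 stands at the limit of > 25000 nM in this assay, at which 1 of the 3 values shown sits. This figure is a limit and not a number. Compound 4 `CCC(C)NC(=C\C(=O)/C=C/c1ccc(OC(C)=O)c(OC)c1)/C=C/c1ccc(OC(C)=O)c(OC)c1` differs from compound 2 in one place: sec-butyl in place of isobutyl on an amine nitrogen. It carries sec-butyl in place of isobutyl on an amine nitrogen. Going by the values given here, one measured step bears on this nitrogen, an at least 5.6-fold higher number from compound 1 to compound 2 (0.75 log units; beyond the scatter). A smaller step than that one is expected here, toward a lower number in this assay, and compound 4 may well reach the same limit. The expected change is an at least 1.6-fold lower number from compound 2 to compound 4 (0.22 log units; that floor lies within the scatter). Compound 4 is estimated at 15000 nM, with an expected range of 5000 nM to 30000 nM.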

Compound 4, half-maximal inhibitory concentration: 24000 nM
Compound 4: the middle estimate sits 1.6-fold (0.20 log units) below what was measured, and the stated range covers the measured number.
By their numbers in this assay, from the lowest: compounds 1 and 3 (each within the scatter of the next); then compound 4. At a limit, above all of these: compound 2.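

With sec-butyl on the amine nitrogen, an open chain at this position now has a real number in this assay, and replacing cyclohexyl with it gives a 5.5-fold higher number from compound 1 to compound 4 (0.74 log units; beyond the scatter). Putting sec-butyl in place of isobutyl gives an at least 1.0-fold lower number from compound 2 to compound 4 (0.01 log units; that floor lies within the scatter), so this change shows no effect that can be told apart from the scatter. The figure for compound 2 is a limit and not a number: the limit of > 25000 nM in this assay, at which 1 of the 4 values shown sits.

Still open, going by these compounds, is whether a cyclopentyl ring, a benzyl group or a longer chain on this nitrogen would stay level with compound 1 or fall toward compound 4.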